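Adding a nitro group to compound 2

The compounds below may be only part of what the source reports. "The series", "measured", "known", "first", "only" and "open" are said of these compounds alone.

In a functional assay on the whole organism for inhibition, with Felis catus as the target, with a stated time of 30 min (on this read-out higher numbers stand for an effect only at larger amounts of compound and lower numbers for an effect already at smaller amounts), compound 1 `OC(CNCCOc1ccc(Cl)cc1)COc1ccccc1` gives 0.08 mg/kg and compound 2 `COCCNCC(O)COc1ccccc1` gives 0.13 mg/kg, so compound 2 stands within the scatter of compound 1. Compound 3 `COCCNCC(O)COc1ccccc1[N+](=O)[O-]` differs from compound 2 in one place: nitro in place of hydrogen on an aromatic carbon. This puts nitro in place of hydrogen on an aromatic carbon, ortho to a large group. For the measured compounds named here, the only measured step, a 1.6-fold higher number from compound 1 to compound 2 (0.21 log units; within the scatter), concerns a different place, an oxygen on a saturated carbon, so it offers little guidance here. The expected change is therefore a 1.1-fold lower number from compound 2 to compound 3 (0.03 log units; within the scatter), nothing beyond the scatter. For compound 3 the estimated value is 0.12 mg/kg, with a range from 0.04 mg/kg to 0.4 mg/kg.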

Compound 3, dose for half-maximal effect: 0.293 mg/kg
Compound 3: the middle estimate sits 2.4-fold (0.39 log units) below what was measured; low and high end bracket the measured number.
By their numbers in this assay, from the lowest: compounds 1 and 2 (each within the scatter of the next); then compound 3.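

In this assay, nitro in place of hydrogen on an aromatic carbon, ortho to a large group, gives a 2.3-fold higher number from compound 2 to compound 3 (0.35 log units; beyond the scatter). This is the first change shown to move the number beyond the scatter, so this position is not indifferent to substitution: with nitro there, a larger dose is needed for the same effect. Nothing available here explains the shift. From the compounds shown here alone, it remains open whether an amine or a methoxy group on this same carbon would shift the number as well, or whether the shift is specific to nitro.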